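Replacing the 1,3-thiazol-2-yl group of compound 2

This account rests on a few compounds, and the source may have more. Where it says the series, first, only, none or still open, it means among the compounds named here.

Compound 1 `CCCCNc1nc(N)nc2ccn(Cc3ccccn3)c12` and compound 2 `Nc1nc(NCc2nccs2)c2c(ccn2Cc2ccccn2)n1` share the same core and differ in one group on a saturated chain carbon bound to a nitrogen on an aromatic ring. In an ADME assay on HEK293 cells (Homo sapiens) for cytotoxicity, read by ATP content, with a stated time of 6 h (a higher number here means that more compound is tolerated, a lower number that less compound is tolerated), compound 1 gives > 24000 nM, which is a limit and not a number. In this assay compound 2 gives > 24000 nM, also a limit. Compound 2 therefore offers no number as a starting point, only (the limit of > 24000 nM in this assay, at which 2 of the 2 values shown sit).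

Compound 3 `Cc1cc(CNc2nc(N)nc3ccn(Cc4ccccn4)c23)on1` keeps the core and carries 3-methyl-1,2-oxazol-5-yl in place of 1,3-thiazol-2-yl at that same place: 3-methyl-1,2-oxazol-5-yl in place of 1,3-thiazol-2-yl on a saturated chain carbon bound to a nitrogen on an aromatic ring.

For the measured compounds named here, one measured step bears on this change: a step that the two limits leave unreadable from compound 1 to compound 2. It has no readable size, so it offers no sign of a change at this place, and neither of its compounds yields a number. No step beyond the scatter is therefore expected in this assay, in either direction, and another limit is the likeliest report. The expected size is a number no higher from compound 2 to compound 3 (the limit leaves the size open). The estimate for compound 3 is 24000 nM, with an expected range from 12000 nM to 48000 nM.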

Compound 3, half-maximal cytotoxic concentration: > 24000 nM
Compound 3: only a limit was reported; the forecaster's own chance of this, stated with the estimate: 85%; the middle value sits exactly at the limit.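

No step can be read in this assay among compound 1, compound 2 and compound 3, as each gives only a limit and not a number: the limit of > 24000 nM in this assay, at which 3 of the 3 values shown sit.

The compounds shown leave open what the actual half-maximal cytotoxic concentrations are, and whether the group on the saturated chain carbon bound to a nitrogen on an aromatic ring affects them at all.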